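Adding a second trifluoromethyl to a weakly cytotoxic ketone

The source may hold more compounds than are shown below. What is called first, only, known or untested is meant among the compounds shown, and "the series" means these compounds.

Measured compounds:
- compound 1, `Cc1ccc(C(=O)CCN2CCN(c3ccc(C(F)(F)F)cc3)CC2)cc1`: 140000 nM
- compound 2, `Cc1ccc(C(=O)CCN2CCN(c3ccc([N+](=O)[O-])cc3)CC2)cc1`: 235000 nM

In an ADME assay on Vero cells (Chlorocebus sabaeus) for cytotoxicity, read by resazurin assay, with a stated time of 72 h (a lower number here means a stronger inhibitor, a higher number a weaker inhibitor), compound 1 gives the lowest of the two numbers shown; compound 2 sits a short way from it, by a 1.7-fold higher number from compound 1 to compound 2 (0.22 log units; within the scatter), which is within the scatter, so the two cannot be ranked. Compound 3, `O=C(CCN1CCN(c2ccc(C(F)(F)F)cc2)CC1)c1ccc(C(F)(F)F)cc1`, differs from compound 1 by trifluoromethyl in place of methyl on an aromatic carbon. Among the measured compounds shown here, no measured step touches this position; the only known step, from compound 1 to compound 2, changes the other ring and moves the number hardly at all. Because a 1.7-fold higher number from compound 1 to compound 2 (0.22 log units; within the scatter) stays within the scatter, the expectation for compound 3 is also a small move, with no direction beyond the scatter, by a 1.2-fold lower number from compound 1 to compound 3 (0.07 log units; within the scatter). Compound 3 is therefore estimated at 120000 nM, with a range from 50000 nM to 300000 nM.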

Compound 3, half-maximal inhibitory concentration: 49200 nM
Compound 3: the middle estimate sits 2.4-fold (0.39 log units) above what was measured; measured number below the stated range.
By their numbers in this assay, from the lowest: compound 3; then compounds 1 and 2 (each within the scatter of the next).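

The earlier compounds shown here varied only the other ring, and that change stayed within the scatter. At the 4-methylphenyl end, in this assay, replacing methyl with trifluoromethyl gives a 2.8-fold lower number from compound 1 to compound 3 (0.45 log units; beyond the scatter) and so makes a modest but readable difference, showing that this position can shift the number even though one pair is thin support for a trend. Nothing available explains why this swap lowers the number.

The compounds shown leave open whether other groups at this position, such as a chlorine atom, a nitrile or a methoxy group, would lower the number as well. They also leave open whether the same swap would give a similar step with nitro in place of trifluoromethyl on the other ring, as in compound 2.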